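Acetamido gives way to 2-oxopyrrolidin-1-yl on the side chain

The compounds below may be only part of what the source reports. "The series", "measured", "known", "first", "only" and "open" are said of these compounds alone.

In an ADME assay (liver) for metabolic stability, with Liver microsome (Canis lupus familiaris) as the target, read by LC-MS, using microsomes, with a stated time of 30 min, tested at 4 uM (a lower number here means that less of the compound is left, a higher number that more of the compound is left), compound 1 `Cc1nc(N2CCN(C)CC2)c2nc(-c3ccccc3Cl)n(CCO)c2n1` gives 99% and compound 2 `CC(=O)NCCn1c(-c2ccccc2Cl)nc2c(N3CCN(C)CC3)nc(C)nc21` gives 40% as the lower of the two numbers. Compound 3 `Cc1nc(N2CCN(C)CC2)c2nc(-c3ccccc3Cl)n(CCN3CCCC3=O)c2n1` shares the same core and has not yet been measured. Its change from compound 2 is 2-oxopyrrolidin-1-yl in place of acetamido on a saturated chain carbon, two bonds along the chain from an aromatic nitrogen at a single place, on a saturated chain carbon, two bonds along the chain from an aromatic nitrogen. In plain words, 2-oxopyrrolidin-1-yl stands in place of acetamido there. Among the compounds with values here, only one measured step bears on this place. That large step a number 59 percentage points lower from compound 1 to compound 2 (beyond the scatter) with acetamido in place of hydroxy lies beyond the scatter and shows that a change here can move the number a long way. Within the data shown here, it does not test the incoming group, and no measured compound carries 2-oxopyrrolidin-1-yl, so the direction remains open. The expected change is a number 5 percentage points higher from compound 2 to compound 3 (within the scatter) and no step beyond the scatter is expected in either direction, though with wide uncertainty. Compound 3 is therefore expected at 45% within an estimated range of 22% to 70% once it is measured in this assay under the same conditions.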

Compound 3, percent of the compound remaining: 60%
Compound 3: middle estimate off by 15 percentage points, on the low side; the measured number falls inside the stated range.
By their numbers in this assay, from the lowest: compound 2; then compound 3; then compound 1.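

In this assay, the change from acetamido to 2-oxopyrrolidin-1-yl gives a number 20 percentage points higher from compound 2 to compound 3 (beyond the scatter), which shows that this place on the side chain responds to more than the loss of hydroxy: the number also moves between two groups that both carry a carbonyl. The entering group adds a five-membered non-aromatic ring and has no hydrogen-bond donor, yet it does not restore the number of the hydroxy compound, as a number 39 percentage points lower from compound 1 to compound 3 (beyond the scatter) makes plain, so both replacements of hydroxy shown here lie lower by a margin beyond the scatter. No measured evidence accompanies these steps to explain why the number moves as it does.

The ring and the loss of the amide hydrogen arrive together in this change, and an open-chain N-methylacetamido group on the same carbon would be needed to tell the two apart. Going by these compounds, how a primary amine, a carboxylic acid or the six-membered 2-oxopiperidin-1-yl would stand at this place also remains open.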